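A few compounds are considered here, and "the series" means these few. Any claim that something is new, unique, unknown or untested is made for them only; others in the source may bear on it.

Measured so far:
compound 1 `O=C(Nc1ccc(Oc2ccnc3[nH]ccc23)cc1)c1cc2cccnc2n(-c2ccc(Cl)cc2)c1=O` — 280 nM
compound 2 `COc1ccc(-n2c(=O)c(C(=O)Nc3ccc(Oc4ccnc5[nH]ccc45)cc3)cc3cccnc32)cc1` — 1260 nM

In a functional assay on HT-29 cells (Homo sapiens) for antiproliferative activity, read by MTT assay, with a stated time of 72 h (on this read-out higher numbers stand for weaker inhibition and lower numbers for stronger inhibition), compound 2 gives the highest of the two numbers recorded; its nearest neighbour is compound 1, and the step of a 4.5-fold higher number from compound 1 to compound 2 (0.65 log units; beyond the scatter) came with methoxy in place of chloro on an aromatic carbon. Compound 3 `O=C(Nc1ccc(Oc2ccnc3[nH]ccc23)cc1)c1cc2cccnc2n(-c2ccc(F)c(Cl)c2)c1=O` is not yet measured. It differs from compound 2 by 3-chloro-4-fluorophenyl in place of 4-methoxyphenyl on an aromatic nitrogen, so the ring bearing the methoxy is exchanged for a ring that carries chloro and fluoro. Among the compounds with values here, only the single step of a 4.5-fold higher number from compound 1 to compound 2 (0.65 log units; beyond the scatter) bears on this change, and it ran towards the higher number when methoxy took the place of chloro. Since compound 3 again carries a chloro on that ring, the expectation for a 3.9-fold lower number from compound 2 to compound 3 (0.60 log units; beyond the scatter) is a step back down in this assay, towards the number of compound 1. The estimated value for compound 3 is therefore 320 nM, with a range from 110 nM to 950 nM.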

Compound 3, half-maximal inhibitory concentration: 560 nM
Beside the measured number, compound 3's estimate is 1.8-fold (0.24 log units) below it, within the range that was stated.
By their numbers in this assay, from the lowest: compounds 1 and 3 (each within the scatter of the next); then compound 2.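

In this assay, the exchange of 4-methoxyphenyl for 3-chloro-4-fluorophenyl on the aromatic nitrogen comes with a 2.3-fold lower number from compound 2 to compound 3 (0.35 log units; beyond the scatter) and shows that the 4-chlorophenyl of compound 1 is not the only halogen-bearing ring to give a lower number than compound 2 does. Set against compound 1, the new ring gives a 2.0-fold higher number from compound 1 to compound 3 (0.30 log units; within the scatter), so the two halogen-bearing compounds cannot be told apart in this read-out. Nothing available gives a cause for either step.

The three compounds leave open whether chloro is needed at all on this ring, since a plain phenyl or a 4-fluorophenyl would test that directly. They also leave open how an amine, a carboxylic acid or a longer alkyl chain on the ring would compare with methoxy and the halogens.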